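Removing a Methoxy Group from a Weak Antiproliferative Sulfonamide

The compounds below may be only part of what the source reports. "The series", "measured", "known", "first", "only" and "open" are said of these compounds alone.

Measured compounds:
- compound 1 `O=C1COc2ccc(-c3cccc(NS(=O)(=O)c4ccc(F)cc4)c3)cc2N1C1CC1`: > 40000 nM
- compound 2 `COc1cccc(N2C(=O)COc3ccc(-c4cnc(Cl)c(NS(=O)(=O)c5ccc(F)cc5)c4)cc32)c1`: 32700 nM

Of the compounds shown here, two have been tested in a functional assay on A549 cells (Homo sapiens) for antiproliferative activity, read by MTT assay, with a stated time of 72 h; on this read-out lower numbers stand for stronger inhibition and higher numbers for weaker inhibition. Compound 1 `O=C1COc2ccc(-c3cccc(NS(=O)(=O)c4ccc(F)cc4)c3)cc2N1C1CC1` gives only a limit of the assay, > 40000 nM, so no number is known for it. Compound 2 `COc1cccc(N2C(=O)COc3ccc(-c4cnc(Cl)c(NS(=O)(=O)c5ccc(F)cc5)c4)cc32)c1`, which carries a chlorine-bearing aromatic ring and a 3-methoxyphenyl group on the core nitrogen, gives 32700 nM in this assay. Among the measured compounds shown here, this is the only actual number in the set, and it stands at the weak end of what the assay can report; the other entry is a limit at which one of the two values sits (the limit of > 40000 nM in this assay, at which 1 of the 2 values shown sits).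

Compound 3 `O=C1COc2ccc(-c3cnc(Cl)c(NS(=O)(=O)c4ccc(F)cc4)c3)cc2N1c1ccccc1` differs from compound 2 in a single place: hydrogen in place of methoxy on an aromatic carbon. The chlorine-bearing ring and the sulfonamide are kept unchanged.

For the measured compounds named here, no measured pair in this set shows what such a change does, so the expected step rests on the weak potency of compound 2 alone. Removing a small group from the edge of the molecule is expected to move the number little, if at all, in either direction; the estimated step from compound 2 to compound 3 is a 1.1-fold higher number from compound 2 to compound 3 (0.03 log units; within the scatter), which stays within the scatter. Compound 3 is therefore estimated at 35000 nM, with a likely range from 12000 nM to 100000 nM in this assay, and a real chance that only a limit is reported.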

Compound 3, half-maximal inhibitory concentration: 14700 nM
Compound 3: middle estimate off by 2.4-fold (0.38 log units), on the high side, within the range that was stated.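

In this assay the change from 3-methoxyphenyl to phenyl gives a 2.2-fold lower number from compound 2 to compound 3 (0.35 log units; beyond the scatter) and shows that the number does respond to what this ring carries, a point that compound 2 alone could not settle. The methoxy group is not required for the activity seen here: compound 3, with the plain phenyl ring, retains it and moves modestly towards stronger inhibition, although compound 3 still gives a weak 14700 nM in this assay. The data shown offer no measurement that explains why the number moved.

Going by these compounds, it remains open whether removing the methoxy group is what matters or whether a different group in its place, such as a fluorine, a hydroxyl or an amine, would give a similar or a larger change. Compound 1 gives only a limit of > 40000 nM and differs from compound 2 in more than one place, so it cannot show how a cyclopropyl group on the core compares with the aromatic rings of the other compounds.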